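The source may hold more compounds than are shown below. What is called first, only, known or untested is meant among the compounds shown, and "the series" means these compounds.

Of the compounds shown here, two have so far been measured in an ADME assay on microsomes from liver (Homo sapiens) for metabolic stability, read by LC-MS, using NADPH, with stated times of 5 min and 30 min, tested at 1 uM; a lower number here means slower removal, a higher number faster removal of the compound. Compound 1 `Cc1ncccc1-c1cnc(NCc2c(F)ccc3c2CCO3)c2n[nH]c(=O)n12` gives 8 mL.min-1.g-1, and compound 2 `CC1(C)CC(=O)N(c2cnc(NCc3c(F)ccc4c3CCO4)n3cnnc23)C1` gives 16 mL.min-1.g-1. Compound 2 carries the higher of the two numbers, but the gap to compound 1 lies within the usual scatter of repeated measurements, so on these figures the two compounds cannot be told apart. Compound 3 `Fc1ccc2c(c1CNc1ncc(Nc3ccccc3)c3nncn13)CCO2` has not yet been measured in this assay. It differs from compound 2 in a single place: anilino in place of 4,4-dimethyl-2-oxopyrrolidin-1-yl on an aromatic carbon. Going by the values given here, no pair of measured compounds that differ in only one place is available here, so there is no measured step of this kind to lean on, and the expectation rests on the two measured values and the nature of the change alone. The change is expected to move the number upward by a modest amount, a 1.9-fold higher number from compound 2 to compound 3 (0.27 log units; within the scatter), somewhat beyond the scatter but not far beyond it. On that basis compound 3 is estimated at 30 mL.min-1.g-1 in this assay, with a plausible range from 12 mL.min-1.g-1 to 75 mL.min-1.g-1.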

Compound 3, intrinsic clearance in microsomes: 20 mL.min-1.g-1
For compound 3 the middle estimate is 1.5-fold (0.18 log units) above the measured one; low and high end bracket the measured number.
By their numbers in this assay, from the lowest: compounds 1, 2 and 3 (each within the scatter of the next, the first and the last beyond it).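

Going by these compounds alone, putting anilino in place of 4,4-dimethyl-2-oxopyrrolidin-1-yl on this aromatic carbon gives a 1.3-fold higher number from compound 2 to compound 3 (0.10 log units; within the scatter) in this assay and so provides the first measured single-place step at this position. The exchange swaps a five-membered non-aromatic ring for a six-membered aromatic ring of carbon only and brings in a hydrogen-bond donor, yet compound 2 and compound 3 cannot be told apart on this read-out, so at this position and on this core, a substantial change of structure need not produce a measurable difference. No measurement shown accounts for this outcome.

From the compounds shown here alone, both groups tested here are fairly large and are attached through nitrogen, so it remains open whether a small group such as methoxy, or a saturated ring amine such as morpholine, would give a number that can be told apart from those of compound 2 and compound 3. Going by these compounds, it also remains open whether the hydrogen on the anilino nitrogen has any bearing on the number, which a methylated anilino could test.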